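The source may report more compounds than this note shows. Statements on the series, on what has been measured and on what is new or still open speak of the compounds shown alone.

In a functional assay on A549 cells (Homo sapiens), read by MTT assay, with a stated time of 3 days (a lower number here means a stronger inhibitor, a higher number a weaker inhibitor), compound 1 `CNc1ncnc2[nH]cc(Sc3cccs3)c12` gives 28600 nM. Compound 2 `Cc1ncnc2[nH]cc(Sc3cccs3)c12` gives > 50000 nM, which is a limit of the assay and not a number. Compound 2 therefore has no exact place on the scale, and any comparison with it has to start from that limit.

Compound 3 `COc1ncnc2[nH]cc(Sc3cccs3)c12` keeps the shared core and changes one group: methoxy in place of methyl on an aromatic carbon. This puts methoxy in place of methyl on an aromatic carbon, next to the ring nitrogen.

Within the data shown here, only one measured step bears on this change, and it concerns the same carbon: an at least 1.7-fold higher number from compound 1 to compound 2 (0.24 log units; that floor lies within the scatter). Among the measured compounds shown here, that step gives only a floor, and no methoxy compound has been measured, so the guide is rough. For the measured compounds named here, with compound 1 at 28600 nM as the only true number nearby, no large step is expected in this assay. Compound 3 may well report only a limit too. The expected change, an at least 1.2-fold lower number from compound 2 to compound 3 (0.09 log units; that floor lies within the scatter), is small and its direction is uncertain. Compound 3 is estimated at 40000 nM, with an expected range from 15000 nM to 90000 nM.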

Compound 3, half-maximal inhibitory concentration: 21500 nM
Beside the measured number, compound 3's estimate is 1.9-fold (0.27 log units) above it; low and high end bracket the measured number.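

In this assay, putting methoxy in place of methyl on this aromatic carbon, next to the ring nitrogen, turns a limit into a true reading, with an at least 2.3-fold lower number from compound 2 to compound 3 (0.36 log units; beyond the scatter). Replacing methylamino with methoxy gives a 1.3-fold lower number from compound 1 to compound 3 (0.12 log units; within the scatter), so these two groups cannot be told apart in this assay, and of the three groups shown, only methyl fails to give an exact number. As far as these compounds go, the step from methyl remains only a floor, and its full size is unknown, since the value of compound 2 is a limit and not a number: the limit of > 50000 nM in this assay, at which 1 of the 3 values shown sits.

The compounds shown leave open how this carbon would respond to other groups, such as a free amine, a carboxylic acid or a longer chain like ethoxy, and whether any of them would shift the number by well beyond the scatter. Among these compounds, with only three groups at one carbon, it also remains unclear whether methoxy and methylamino match for a shared reason or by chance, and no data here point to a cause.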